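Removing the Last Ring Substituent: Fluoro to Hydrogen

The source may report more compounds than this note shows. Statements on the series, on what has been measured and on what is new or still open speak of the compounds shown alone.

Compound 1, `C[C@@H]1CN(Cc2ccccc2)c2nc(C(F)(F)F)ccc2[C@H](C)N1C(=O)NCc1ccccc1`, gives 104 nM in an assay on HEK293 cells for inhibition of Voltage-dependent T-type calcium channel subunit alpha-1H (Homo sapiens), read by FLIPR and calcium flux, with a stated time of 3 min; on this read-out lower numbers stand for stronger inhibition and higher numbers for weaker inhibition.
Compound 2, `C[C@@H]1CN(Cc2ccccc2)c2nc(F)ccc2[C@H](C)N1C(=O)NCc1ccccc1`, gives 6 nM in this assay.

Of the two numbers, compound 2 holds the lower one; the gap that separates it from compound 1 is a 17-fold lower number from compound 1 to compound 2 (1.24 log units; beyond the scatter), a large step beyond the scatter. Compound 3, `C[C@@H]1CN(Cc2ccccc2)c2ncccc2[C@H](C)N1C(=O)NCc1ccccc1`, differs from compound 2 only by hydrogen in place of fluoro on an aromatic carbon. Within the data shown here, the single measured step bears on this change only in part: it shows what the exchange of trifluoromethyl for fluoro did on the same aromatic carbon, but no measured pair shows what the loss of the fluoro itself does. Compound 3 is therefore expected to stay close to that low value, with an expected step of a 1.7-fold higher number from compound 2 to compound 3 (0.22 log units; within the scatter) that may well remain within the scatter. Compound 3 is estimated at 10 nM in this assay, with a range from 3 nM to 35 nM.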

Compound 3, half-maximal inhibitory concentration: 31 nM
Estimate against measurement, compound 3: 3.1-fold (0.49 log units) below, and the stated range covers the measured number.
By their numbers in this assay, from the lowest: compound 2; then compound 3; then compound 1.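

The loss of the fluoro on this aromatic carbon next to the ring nitrogen is not neutral in this assay (a 5.2-fold higher number from compound 2 to compound 3 (0.71 log units; beyond the scatter)), so the low number of compound 2 depends on the fluoro itself and not merely on the absence of trifluoromethyl. Hydrogen also gives a lower number than trifluoromethyl (a 3.4-fold lower number from compound 1 to compound 3 (0.53 log units; beyond the scatter)), which places compound 3 between the other two and shows that the position responds in both directions relative to hydrogen. Nothing measured here accounts for this order among the three groups.

Still open, on these data alone, is how a chloro, a methoxy, a nitrile or an amine on the same carbon would fall relative to fluoro and hydrogen. As far as these compounds go, whether the order of these three groups would hold with another group in place of either benzyl on the shared core also remains unknown.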